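Swapping a Methylphenyl Ether for a Fluorophenyl Ether

A few compounds are considered here, and "the series" means these few. Any claim that something is new, unique, unknown or untested is made for them only; others in the source may bear on it.

Among the measured compounds shown here, compound 2 `Cc1ccc(OC(C)(C)C2OCC(C/C=C\CCC(=O)O)C(c3cccnc3)O2)cc1` gives 360 nM in an assay for inhibition of Thromboxane-A synthase (Homo sapiens), using microsomes (on this read-out lower numbers stand for stronger inhibition and higher numbers for weaker inhibition), the highest of the two numbers measured so far, while compound 1 `Cc1ccc(C#N)c(OC(C)(C)C2OCC(C/C=C\CCC(=O)O)C(c3cccnc3)O2)c1` gives 50 nM in this assay. For the measured compounds named here, the one measured step, a 7.2-fold higher number from compound 1 to compound 2 (0.86 log units; beyond the scatter), shows that the aromatic ring on this ether oxygen has a clear effect on inhibition. Compound 3 `CC(C)(Oc1ccccc1F)C1OCC(C/C=C\CCC(=O)O)C(c2cccnc2)O1` carries the change (2-fluorophenyl in place of 4-methylphenyl on an oxygen on a saturated carbon). Going by the values given here, no measured step covers a fluorine on this ring, so the direction rests on that single step and remains uncertain. The expectation for compound 3 is a small gain, a 1.8-fold lower number from compound 2 to compound 3 (0.26 log units; within the scatter), with an estimated value of 200 nM and a likely range of 60 nM to 700 nM.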

Compound 3, half-maximal inhibitory concentration: 45 nM
Estimate against measurement, compound 3: 4.4-fold (0.65 log units) above, outside the stated range (below it).
By their numbers in this assay, from the lowest: compounds 3 and 1 (each within the scatter of the next); then compound 2.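

The swap of 4-methylphenyl for 2-fluorophenyl on this ether oxygen gives an 8.0-fold lower number from compound 2 to compound 3 (0.90 log units; beyond the scatter), so the ring on this oxygen matters even when its heavy-atom count stays the same. The other step, a 1.1-fold lower number from compound 1 to compound 3 (0.05 log units; within the scatter), places 2-fluorophenyl level with 2-cyano-5-methylphenyl, so a nitrile is not needed on this ring for a low number. Nothing available here explains these differences. Going by these compounds, whether a chlorine or a methoxy group in place of the fluorine would keep this inhibition remains open.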